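Swapping methyl for fluoro on the sulfonyl-side ring

This account rests on a few compounds, and the source may have more. Where it says the series, first, only, none or still open, it means among the compounds named here.

compound 1 `Cc1ccc(NS(=O)(=O)c2ccccc2)c([N+](=O)[O-])c1` gives 60300 nM
compound 2 `O=S(=O)(Nc1ccccc1)c1ccccc1` gives > 100000 nM (a limit)
compound 3 `Cc1ccc(S(=O)(=O)Nc2ccc(C)cc2[N+](=O)[O-])cc1` gives 43700 nM

Among the compounds with values here, in a functional assay on PC-3 cells (Homo sapiens) for cytotoxicity, read by MTT assay, with a stated time of 5 days (a lower number here means a stronger inhibitor of growth, a higher number a weaker inhibitor of growth), compound 3 gives 43700 nM and stands level, within the scatter, with compound 1 at 60300 nM as the only other true number. Compound 2 at > 100000 nM is a limit of the assay and not a number.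

Compound 4 `Cc1ccc(NS(=O)(=O)c2ccc(F)cc2)c([N+](=O)[O-])c1` keeps the rest of compound 3 and carries fluoro in place of methyl on an aromatic carbon as its single difference. Within the data shown here, one measured step bears on this change: a 1.4-fold lower number from compound 1 to compound 3 (0.14 log units; within the scatter) is methyl in place of hydrogen, and it lies within the scatter. The methyl gained in that step is the same group that leaves in compound 4. Among the measured compounds shown here, no measured compound carries fluoro, so the evidence is thin.

On the strength of a 1.4-fold lower number from compound 1 to compound 3 (0.14 log units; within the scatter) alone, no step beyond the scatter is expected in this assay in either direction. The estimated step is small: a 1.1-fold higher number from compound 3 to compound 4 (0.06 log units; within the scatter) and no more than that is expected. For compound 4 the estimated value is 50000 nM with an expected range of 25000 nM to 100000 nM in this assay for now.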

Compound 4, concentration for 50% growth inhibition: 850 nM
Compound 4: the middle estimate sits 59-fold (1.77 log units) above what was measured; the measured number lies below the stated range.
By their numbers in this assay, from the lowest: compound 4; then compounds 3 and 1 (each within the scatter of the next). At a limit, above all of these: compound 2.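

In this assay, the aromatic carbon para to a large group proves highly sensitive to what it carries: a 51-fold lower number from compound 3 to compound 4 (1.71 log units; beyond the scatter) for 4-methylphenyl to 4-fluorophenyl, and a 71-fold lower number from compound 1 to compound 4 (1.85 log units; beyond the scatter) for fluoro in place of hydrogen. Methyl on that same carbon gave only a 1.4-fold lower number from compound 1 to compound 3 (0.14 log units; within the scatter), so the earlier compounds showed no response at this position, and hydrogen and methyl there stay within the scatter of each other while fluoro stands well apart from both. Methyl and fluoro match in heavy-atom count and in hydrogen-bond donors and acceptors, and nothing measured in this series accounts for the size of the change.

On these data alone, whether the gain belongs to fluoro alone stays open, and chloro, methoxy, nitrile or an amine on the same carbon would test how narrow the requirement is. As far as these compounds go, it is also open whether the gain carries over when the nitro group or the methyl on the other ring of the shared core is replaced, for instance by an amine or a carboxylic acid.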